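The compounds below may be only part of what the source reports. "The series", "measured", "known", "first", "only" and "open" are said of these compounds alone.

Working notes on the cyanoguanidine series.

Compound 1 `N#CN/C(=N\CCOC(=O)c1ccccc1)NCCCOc1cccc(CN2CCCCC2)c1` is the stronger of the two compounds measured in a functional assay on cardiac atrium for antagonist activity at histamine H2 receptor (Cavia porcellus); a lower number here means a less potent compound, a higher number a more potent compound, by a factor of ten per unit of this negative logarithm: compound 1 gives 7.64, while compound 2 `N#CN/C(=N\CCCNC(=O)c1ccc(N=[N+]=[N-])cc1)NCCCOc1cccc(CN2CCCCC2)c1` gives 6.36 in this assay, a gap beyond the usual scatter. Going by the values given here, compound 1 therefore stands at the top of the numbers so far.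

Compound 3 `Cc1ccc(S(=O)(=O)NCC/N=C(\NC#N)NCCCOc2cccc(CN3CCCCC3)c2)cc1` has not yet been measured. It differs from compound 1 as follows: ((4-methylphenyl)sulfonyl)amino in place of benzoyloxy on a saturated chain carbon, two bonds along the chain from a double-bonded nitrogen. The chain and the shared core are kept; only the group on the saturated chain carbon, two bonds along the chain from the double-bonded nitrogen, is exchanged. Among the compounds with values here, no step between measured compounds covers this exchange, so the expected size of the change rests on the structural difference alone.

A modest loss relative to compound 1 is expected, a step of a number 0.64 log units lower from compound 1 to compound 3 (beyond the scatter) in this assay. Compound 3 is thus estimated at 7, within a range from 6.3 to 7.7.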

Compound 3, negative logarithm of the antagonist equilibrium constant: 6.13
Estimate against measurement, compound 3: 0.87 log units above; measured number outside the range, below it.
By their numbers in this assay, from the lowest: compounds 3 and 2 (each within the scatter of the next); then compound 1.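

At the position on a saturated chain carbon, two bonds along the chain from a double-bonded nitrogen, the exchange of benzoyloxy for ((4-methylphenyl)sulfonyl)amino is far from neutral in this assay: the change runs a number 1.51 log units lower from compound 1 to compound 3 (beyond the scatter) and counts as large. Both groups carry one six-membered aromatic ring of carbon only, so the presence of such a ring in the entering group does not by itself preserve the number of compound 1. Nothing available bears on what lies behind this step.

With only this one exchange at the position, the compounds shown leave open which part of the entering group carries the step. A plain benzoylamino group and a phenylsulfonylamino group at the same place would separate the linking atoms from the ring methyl.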